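Hydrazide Sulfonamides: Sulfonyl Ring Substituent Swap

This account rests on a few compounds, and the source may have more. Where it says the series, first, only, none or still open, it means among the compounds named here.

Compound 1 `CC(=O)Nc1ccc(S(=O)(=O)NNc2ccc(C)cc2)cc1` gives 51 nM. Compound 2 `COc1ccc(NNS(=O)(=O)c2ccc(NC(C)=O)cc2)cc1` gives 254 nM. Compound 3 `N#Cc1ccc(S(=O)(=O)NNc2ccc(Br)cc2)cc1` gives 176 nM.

In an assay for inhibition of Indoleamine 2,3-dioxygenase 1 (Homo sapiens), read by spectrophotometry, with stated times of 1 h and 4 h (on this read-out higher numbers stand for weaker inhibition and lower numbers for stronger inhibition), compound 3 stands second highest of the three numbers; its gap to compound 2 lies within the scatter, while compound 1 sits beyond it. Compound 4 `O=C(O)COc1ccc(S(=O)(=O)NNc2ccc(Br)cc2)cc1` differs from compound 3 by carboxymethoxy in place of cyano on an aromatic carbon. Going by the values given here, the only measured step, a 5.0-fold higher number from compound 1 to compound 2 (0.70 log units; beyond the scatter), concerns the other ring and does not bear directly on this change; nothing measured covers the sulfonyl ring substituent. The estimate therefore leans on compound 3 alone, allowing for a modest weakening of uncertain size. Compound 4 is expected to give 300 nM, within 100 nM to 1200 nM, a step of a 1.7-fold higher number from compound 3 to compound 4 (0.23 log units; within the scatter).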

Compound 4, half-maximal inhibitory concentration: 125 nM
Compound 4: the middle estimate sits 2.4-fold (0.38 log units) above what was measured; low and high end bracket the measured number.
By their numbers in this assay, from the lowest: compound 1; then compounds 4, 3 and 2 (each within the scatter of the next, the first and the last beyond it).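

Carboxymethoxy in place of cyano gives a 1.4-fold lower number from compound 3 to compound 4 (0.15 log units; within the scatter) in this assay, the first reading on a substituent of the sulfonyl ring, since the earlier step concerned the other ring. This position, para to a large group, thus accommodates a group of five heavy atoms that carries a hydrogen-bond donor, with no change beyond the scatter. No evidence on hand explains this result.

The compounds shown leave open whether an amine or a longer chain ending in a carboxylic acid would be accommodated equally at this position.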